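Dropping the Fluoro Group from Compound 2

This account rests on a few compounds, and the source may have more. Where it says the series, first, only, none or still open, it means among the compounds named here.

Of the compounds shown here, two have been measured in a functional assay on MCF7 cells (Homo sapiens) for inhibition, in the absence of a further agent (a lower number here means a stronger inhibitor, a higher number a weaker inhibitor), so far.

- compound 1 `Nc1ccc(-c2cc(=O)c3c(N)ccc(F)c3o2)cc1` gives 6.9 nM
- compound 2 `Nc1ccc(-c2cc(=O)c3c(N)c(F)ccc3o2)cc1` gives 4.4 nM

Compound 2 stands level with compound 1 on these numbers, since the two values lie within the scatter of each other. The next compound to be measured is compound 3 `Nc1ccc(-c2cc(=O)c3c(N)cccc3o2)cc1`, which has hydrogen in place of fluoro on an aromatic carbon, the carbon that stands ortho to an amino group hydrogen in place of fluoro on an aromatic carbon in compound 2. Going by the values given here, no measured compound lacks fluoro, so the data offer no direct measure of this change. Compound 1 at 6.9 nM and compound 2 at 4.4 nM give no sign of a large shift, so no step beyond the scatter is expected in this assay in either direction. The expected change is a 1.4-fold higher number from compound 2 to compound 3 (0.13 log units; within the scatter) and remains only an estimate. In this assay compound 3 is estimated at 6 nM with an expected range from 2.5 nM to 15 nM as its limits.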

Compound 3, half-maximal inhibitory concentration: 7.3 nM
Estimate against measurement, compound 3: 1.2-fold (0.09 log units) below, within the range that was stated.
By their numbers in this assay, from the lowest: compounds 2, 1 and 3 (each within the scatter of the next).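

In this assay, going by these compounds alone, the first direct reading of this change at the aromatic carbon ortho to an amino group is a 1.7-fold higher number from compound 2 to compound 3 (0.22 log units; within the scatter) and the same exchange from the other fluoro compound is a 1.1-fold higher number from compound 1 to compound 3 (0.02 log units; within the scatter) on the shared core. Both steps lie within the scatter, so on these three compounds fluoro is not required at either place for a number of this size, and compound 3 stands level with compound 2 and compound 1. Nothing at hand gives a reason for this result.

The compounds shown leave open whether a larger group on this carbon, such as chloro, methyl or methoxy, would stay level with hydrogen and fluoro. They also leave open whether a hydroxyl group in place of the amino group ortho to this carbon would leave the number within the scatter.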